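A few compounds are considered here, and "the series" means these few. Any claim that something is new, unique, unknown or untested is made for them only; others in the source may bear on it.

The three compounds measured in a functional assay on HCT-116 cells (Homo sapiens) for cytotoxicity, read by MTT assay, with a stated time of 48 h (on this read-out lower numbers stand for stronger inhibition and higher numbers for weaker inhibition), are:

compound 1, `Cc1nc2c3ccccc3ccc2c2nc3c(ccc4ccccc43)c(-c3cccc([N+](=O)[O-])c3)c12`: 13200 nM
compound 2, `Cc1nc2c3ccccc3ccc2c2nc3c(ccc4ccccc43)c(-c3ccccc3Cl)c12`: 48200 nM
compound 3, `Cc1nc2c3ccccc3ccc2c2nc3c(ccc4ccccc43)c(-c3ccccc3S)c12`: 1420 nM

Compound 3 gives the lowest number of the three, and both steps toward it lie beyond the scatter: a 9.3-fold lower number from compound 1 to compound 3 (0.97 log units; beyond the scatter) and a 34-fold lower number from compound 2 to compound 3 (1.53 log units; beyond the scatter). The step of a 3.7-fold higher number from compound 1 to compound 2 (0.56 log units; beyond the scatter) shows that the two other substituted phenyl groups also differ from one another.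

Compound 4, `Cc1nc2c3ccccc3ccc2c2nc3c(ccc4ccccc43)c(-c3ccccc3)c12`, differs from compound 3 by hydrogen in place of sulfanyl on an aromatic carbon. Among the measured compounds shown here, no measured step removes a group from this phenyl ring to leave hydrogen, so the comparison rests on the exchanges at the same position. The step of a 34-fold lower number from compound 2 to compound 3 (1.53 log units; beyond the scatter) is large, and a 9.3-fold lower number from compound 1 to compound 3 (0.97 log units; beyond the scatter) is modest; in both the sulfanyl compound stands far below its partner. Taking the sulfanyl group away is therefore expected to move the number in this assay upward, beyond the scatter, though how far is uncertain, since neither compound 1 nor compound 2 carries an unsubstituted phenyl.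

Compound 4 is expected to give about 15000 nM in this assay, with a range from 3000 nM to 60000 nM. This estimate corresponds to an 11-fold higher number from compound 3 to compound 4 (1.02 log units; beyond the scatter).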

Compound 4, half-maximal inhibitory concentration: > 80000 nM
Compound 4: no number, only a limit; the forecaster's own chance of this, stated with the estimate: 10%; middle value at least 5.3-fold (0.72 log units) from the limit.
By their numbers in this assay, from the lowest: compound 3; then compound 1; then compound 2. At a limit, above all of these: compound 4.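

For compound 4 the result in this assay is a limit and not a number: the limit of > 80000 nM in this assay, at which 1 of the 4 values shown sits. Among the compounds shown here, the unsubstituted phenyl gives the first direct comparison of sulfanyl with hydrogen on this aromatic carbon, and an at least 56-fold higher number from compound 3 to compound 4 (1.75 log units; beyond the scatter) shows that the low number of compound 3 goes with the sulfanyl group and is not carried by the shared core alone. The other two exchanges read differently: an at least 6.0-fold higher number from compound 1 to compound 4 (0.78 log units; beyond the scatter) sets the nitro compound apart from the unsubstituted phenyl, whereas an at least 1.6-fold higher number from compound 2 to compound 4 (0.22 log units; that floor lies within the scatter) leaves chloro and hydrogen unseparated by this floor.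

The compounds shown leave open whether a hydroxyl, an amine or a methylsulfanyl group on this aromatic carbon would keep the number near that of compound 3, and so whether the sulfur-bearing sulfanyl group itself is needed. Also open, from the compounds shown here alone, is the true size of all three steps to compound 4, since each gives only a floor, and how a sulfanyl group would read elsewhere on this phenyl ring.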